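The source may report more compounds than this note shows. Statements on the series, on what has been measured and on what is new or still open speak of the compounds shown alone.

Working notes on the series sharing the core of compound 1 `CN(C)/C(=N\C#N)C1=CC(C)(C)Oc2ccc([N+](=O)[O-])cc21`. In a functional assay (aorta) with Rattus norvegicus as the target (a higher number here means that more compound is needed for the effect, a lower number that less compound is needed), compound 1 gives > 31600 nM, which is a limit of the assay and not a number.

Going by the values given here, compound 2 `CN(C)/C(=N\C#N)C1=CC(C)(C)Oc2ccc(C#N)cc21` gives 5010 nM, the only actual number so far in this assay. Cyano in place of nitro on an aromatic carbon gave an at least 6.3-fold lower number from compound 1 to compound 2 (0.79 log units; beyond the scatter), and this is the only measured step at that place.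

Compound 3 `CN(C)/C(=N\C#N)C1=CC(C)(C)Oc2ccc(S(=O)(=O)c3ccccc3)cc21` has phenylsulfonyl in place of cyano on an aromatic carbon. The entering group matches neither group in the measured step. That step therefore shows that a change at this place can exceed the scatter, but it gives no direction for compound 3. A wide range in either direction is expected in this assay, with the expected change being a 1.3-fold lower number from compound 2 to compound 3 (0.10 log units; within the scatter). The estimate for compound 3 is 4000 nM, with an expected range from 600 nM to 30000 nM.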

Compound 3, half-maximal effective concentration: 3310 nM
Compound 3: the middle estimate sits 1.2-fold (0.08 log units) above what was measured; the range from low to high includes it.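

In this assay, the change gives a 1.5-fold lower number from compound 2 to compound 3 (0.18 log units; within the scatter), so phenylsulfonyl, with 9 heavy atoms and a six-membered aromatic ring, reads level with cyano, with 2 heavy atoms, at this place. Measured against nitro, the change gives an at least 9.5-fold lower number from compound 1 to compound 3 (0.97 log units; beyond the scatter), so compound 2 and compound 3 both stand clear of compound 1, and a change at this place does not always move the number beyond the scatter. Compound 1 gives a limit and not a number, and the true size of both steps from it stays unknown because of where it sits: the limit of > 31600 nM in this assay, at which 1 of the 3 values shown sits.

From the compounds shown here alone, whether an amine or a carboxylic acid at this place would stay level with cyano and phenylsulfonyl remains open. Also open, going by these compounds, is what methylsulfonyl would show about the phenyl ring of the phenylsulfonyl group.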